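The compounds below may be only part of what the source reports. "The series", "measured", "known", "first", "only" and "open" are said of these compounds alone.

The measured compounds and their numbers in a functional assay on the whole organism (Tail, strain ICR) with Mus musculus as the target, in the tail flick test, with a stated time of 90 min, at a dose of 25 umol/kg by the oral route; on this read-out higher numbers stand for a stronger effect at the one dose given and lower numbers for a weaker effect:

compound 1 `O=C(O)[C@@H]1CCCN1C(=O)CN(c1nc(Cl)nc2[nH]cnc12)C1CC1` gives 26%
compound 2 `O=C(CN(c1ncnc2c1ncn2C1CCCCO1)C1CC1)NCC(=O)OCc1ccccc1` gives 25.9%
compound 3 `O=C(OCc1ccccc1)[C@@H]1CCCN1C(=O)CN(c1ncnc2c1ncn2C1CCCCO1)C1CC1` gives 23.3%

Compound 2 sits among the three with the number of compound 1 a little above it and that of compound 3 a little below it, both differences within the scatter, so nothing separates the three compounds on these readings.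

Compound 4 `O=C(CN(c1ncnc2c1ncn2C1CCCCO1)C1CC1)N[C@@H](CO)C(=O)OCc1ccccc1` has not yet been measured in this assay. It differs from compound 2 by hydroxymethyl in place of hydrogen on a saturated chain carbon bound to an amide-type nitrogen and a carbonyl carbon.

For the measured compounds named here, no step between two measured compounds shows what this change does, so the account can only expect a step in this assay of no more than the scatter, in no particular direction; the expected step is a number 0.1 percentage points higher from compound 2 to compound 4 (within the scatter). Compound 4 is accordingly estimated at 26%, with a range from 14% to 38%.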

Compound 4, a percentage reported as activity, at one dose (the size of the read-out at that dose, not a potency): 32.2%
Beside the measured number, compound 4's estimate is 6.2 percentage points below it, within the range that was stated.
By their numbers in this assay, from the lowest: compounds 3, 2, 1 and 4 (each within the scatter of the next).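

Hydroxymethyl in place of hydrogen on a saturated chain carbon bound to an amide-type nitrogen and a carbonyl carbon is the first single change that can be read in this assay (a number 6.3 percentage points higher from compound 2 to compound 4 (within the scatter)). This position therefore accepts the added group with no loss beyond the scatter, but the step does not separate the two compounds. Nothing measured here explains the step.

On these data alone, whether a methyl, an aminomethyl or a carboxylic acid on this carbon would move the number beyond the scatter stays open.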